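Extending the nitrogen substituent of a cytotoxic quinolinone scaffold

The source may hold more compounds than are shown below. What is called first, only, known or untested is meant among the compounds shown, and "the series" means these compounds.

Compound 1 `COc1ccc(-c2cc3cccc(OC)c3nc2O)cc1` and compound 2 `COc1ccc(-c2cc3c(OC)cc(OC)cc3n(C)c2=O)cc1` share a core in which a methoxyphenyl group hangs from a bicyclic, nitrogen-containing ring system. In a functional assay on A-427 cells (Homo sapiens) for cytotoxicity, read by colorimetric assay and MTT assay (a lower number here means a stronger inhibitor, a higher number a weaker inhibitor), compound 1 gives 10000 nM. In the same assay compound 2 gives 10000 nM. Compound 2 therefore stands level with compound 1 at the digits shown, and no difference between the two can be claimed, as the gap lies within the usual scatter of repeated measurements.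

Compound 3 `COc1ccc(-c2cc3c(OC)cc(OC)cc3n(CCC#N)c2=O)cc1` has not yet been tested. It differs from compound 2 in a single place: cyanomethyl in place of hydrogen on a saturated chain carbon bound to an aromatic nitrogen. Seen from one bond further out, the methyl on the ring nitrogen of compound 2 becomes a 2-cyanoethyl chain in compound 3.

Among the compounds with values here, no measured pair shows what such a change does here, so the expectation rests only on the two values available, both weak. The expected step of no change at the digits printed from compound 2 to compound 3 (within the scatter) is none beyond the scatter, in either direction. For compound 3 the estimated value in this assay is 10000 nM, with a range from 4000 nM to 20000 nM.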

Compound 3, half-maximal inhibitory concentration: 10000 nM
Beside the measured number, compound 3's estimate shows no gap at the digits printed; measured number inside the range.
By their numbers in this assay, from the lowest: compounds 1, 2 and 3 (each within the scatter of the next).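

Replacing the methyl on the ring nitrogen with a 2-cyanoethyl chain gives no change at the digits printed from compound 2 to compound 3 (within the scatter) in this assay. Within the data shown here, this is the first measured step at this position, and it shows that the nitrile-bearing chain can take the place of the methyl without moving the reading beyond the scatter: compound 2 gives 10000 nM and compound 3 gives 10000 nM. Nothing available explains this outcome, and the reading alone cannot say what the chain does in the cells.

From the compounds shown here alone, it remains open whether a chain ending in an amine or a carboxylic acid instead of the nitrile, or a longer chain, would shift the value beyond the scatter. Going by these compounds, it is also open whether the 2-cyanoethyl chain would leave the reading just as unmoved on a related compound with a much lower starting value, as this single step starts from a weak compound and ends at a weak one.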